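Aryl variation on the piperazine nitrogen and cytotoxicity

A few compounds are considered here, and "the series" means these few. Any claim that something is new, unique, unknown or untested is made for them only; others in the source may bear on it.

The measured compounds:
compound 1 `CC(=O)c1ccc(N2CCN(C(=O)c3nc4cc(Cl)ccc4s3)CC2)cc1`, 30.8%
compound 2 `O=C(c1nc2cc(Cl)ccc2s1)N1CCN(c2ccccc2)CC1`, 41.2%
compound 3 `O=C(c1nc2cc(Cl)ccc2s1)N1CCN(c2cnccn2)CC1`, 54.9%

In an ADME assay on RAW264.7 cells (Mus musculus) for cytotoxicity, read by MTT assay, with a stated time of 72 h, tested at 50 ug/mL (on this read-out lower numbers stand for less inhibition and higher numbers for more inhibition at the one concentration tested (going by the name of the read-out)), compound 3 gives 54.9%, the highest of the three numbers. Its nearest neighbour is compound 2, and the step of a number 13.7 percentage points higher from compound 2 to compound 3 (beyond the scatter) lies beyond the scatter; compound 1 stands furthest away, with the step of a number 24.1 percentage points higher from compound 1 to compound 3 (beyond the scatter).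

Compound 4 `COc1ccc(N2CCN(C(=O)c3nc4cc(Cl)ccc4s3)CC2)cc1` has not yet been measured. It differs from compound 3 in one place: 4-methoxyphenyl in place of pyrazin-2-yl on an amine nitrogen in a ring. Two of the measured steps bear on this change. Replacing phenyl by pyrazin-2-yl gave a number 13.7 percentage points higher from compound 2 to compound 3 (beyond the scatter), and replacing 4-acetylphenyl by pyrazin-2-yl gave a number 24.1 percentage points higher from compound 1 to compound 3 (beyond the scatter). Both steps run towards pyrazin-2-yl and both raise the number; compound 4 runs the other way, back to a carbon-only ring carrying a group on it, much like compound 1. A drop of modest size in this assay is therefore expected, beyond the scatter, although compound 1 and compound 2 differ in where they land among themselves. The expected step is a number 18.9 percentage points lower from compound 3 to compound 4 (beyond the scatter). For compound 4 the estimate in this assay is 36%, within a range from 22% to 50%.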

Compound 4, a percentage reported as inhibition, at one concentration (the size of the read-out at that concentration, not a potency): 42.8%
The estimate for compound 4 lay 6.8 percentage points below the measured number; low and high end bracket the measured number.
By their numbers in this assay, from the lowest: compound 1; then compounds 2 and 4 (each within the scatter of the next); then compound 3.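

In this assay, compound 4 shows that a group on the carbon-only ring need not lower the number: methoxy in place of hydrogen gives a number 1.6 percentage points higher from compound 2 to compound 4 (within the scatter), while methoxy in place of acetyl gives a number 12 percentage points higher from compound 1 to compound 4 (beyond the scatter), so among the carbon-only rings only the 4-acetylphenyl compound stands apart. The pyrazin-2-yl compound also stays apart from the 4-methoxyphenyl compound, with a number 12.1 percentage points lower from compound 3 to compound 4 (beyond the scatter), so its gap holds against both phenyl and 4-methoxyphenyl. Nothing at hand explains either difference.

Going by these compounds, it remains open whether the low number belongs to acetyl alone or would also appear with an amine or a carboxylic acid on the aromatic ring. Also open, on these data alone, is whether a pyridine ring on the amine nitrogen would fall with compound 3 or with compound 2 and compound 4.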